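Ring-nitrogen substituent: from hexyl to pyridin-4-yl

The source may report more compounds than this note shows. Statements on the series, on what has been measured and on what is new or still open speak of the compounds shown alone.

Measured so far in an assay on membranes from liver for displacement of a labelled ligand from Sigma intracellular receptor 2 (Rattus norvegicus), read by scintillation counting, with a stated time of 120 min; on this read-out lower numbers stand for stronger inhibition and higher numbers for weaker inhibition:
Compound 1, `Cc1cccc2sc(NC(=O)CCN3CCN(C(C)C)CC3)nc12`: 1800 nM
Compound 2, `CCCCN1CCN(CCC(=O)Nc2nc3c(C)cccc3s2)CC1`: 1200 nM
Compound 3, `CCCCCCN1CCN(CCC(=O)Nc2nc3c(C)cccc3s2)CC1`: 158 nM

Compound 3 gives the lowest number of the three. Its nearest neighbour is compound 2, a 7.6-fold lower number from compound 2 to compound 3 (0.88 log units; beyond the scatter), and its furthest is compound 1, an 11-fold lower number from compound 1 to compound 3 (1.06 log units; beyond the scatter); both gaps lie beyond the scatter. The step of a 1.5-fold lower number from compound 1 to compound 2 (0.18 log units; within the scatter) lies within the scatter.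

Compound 4, `Cc1cccc2sc(NC(=O)CCN3CCN(c4ccncc4)CC3)nc12`, is not yet measured. Its change from compound 3 is pyridin-4-yl in place of hexyl on an amine nitrogen in a ring.

The steps that share this position are those from compound 1 and compound 2 to compound 3, where a longer chain on the ring nitrogen brought a large and a modest drop in the number. Among the measured compounds shown here, no measured step covers an aromatic group, or any group with a hydrogen-bond acceptor, at this position, so those steps bear on the place but not on the kind of change. For the measured compounds named here, the only guide is that the lowest number seen so far belongs to the hexyl chain of compound 3, and compound 4 no longer has it. The expectation in this assay is therefore a higher number than compound 3, with a step of about a 5.7-fold higher number from compound 3 to compound 4 (0.76 log units; beyond the scatter), and wide uncertainty. Compound 4 is estimated at 900 nM, within a range from 200 nM to 4000 nM.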

Compound 4, inhibition constant: 1700 nM
Compound 4: middle estimate off by 1.9-fold (0.28 log units), on the low side; low and high end bracket the measured number.
By their numbers in this assay, from the lowest: compound 3; then compounds 2, 4 and 1 (each within the scatter of the next).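

In this assay, the change from the hexyl chain to pyridin-4-yl gives an 11-fold higher number from compound 3 to compound 4 (1.03 log units; beyond the scatter), so a group with the same heavy-atom count does not by that count alone retain the low number of compound 3. The aromatic ring with its hydrogen-bond acceptor also stands level with the short alkyl groups, with a 1.4-fold higher number from compound 2 to compound 4 (0.15 log units; within the scatter) and a 1.1-fold lower number from compound 1 to compound 4 (0.02 log units; within the scatter), both within the scatter, so among these four compounds only the hexyl chain of compound 3 stands apart. Nothing available on these compounds gives a reason for the large step from hexyl to pyridin-4-yl.

The compounds shown leave open whether the higher number with pyridin-4-yl goes with the aromatic ring or with its ring nitrogen, which a phenyl group at this place would help to separate. They also leave open whether the number keeps falling beyond hexyl with a longer chain such as octyl, and whether a cyclohexyl group would behave like the open chain.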